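This account rests on a few compounds, and the source may have more. Where it says the series, first, only, none or still open, it means among the compounds named here.

Measured so far:
compound 1 `NC1=NC2(CCOCC2)N(OCCCOc2cccc(Cl)c2)C(N)=N1` gives 83.2% in an assay on isolated protein for inhibition of Dihydrofolate reductase (Homo sapiens), read by spectrophotometry, using NADPH, with stated times of 5 s and 6 min, tested at 5 uM; on this read-out lower numbers stand for a weaker effect and higher numbers for a stronger effect at the one concentration tested
compound 2 `NC1=NC2(CCOCC2)N(OCCCOc2ccc(F)cc2)C(N)=N1` gives > 90% in this assay
compound 3 `NC1=NC2(CCSCC2)N(OCCCOc2cccc(Cl)c2Cl)C(N)=N1` gives 83.8% in this assay

Compound 2 is reported only as a limit, namely (the limit of > 90% in this assay, at which 1 of the 3 values shown sits). Of the two plain numbers, compound 3 stands at the top, but its distance to compound 1 lies within the usual scatter, so the two cannot be set apart.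

Compound 4 `NC1=NC2(CCSCC2)N(OCCCOc2ccccc2Cl)C(N)=N1` differs from compound 3 in one place: hydrogen in place of chloro on an aromatic carbon. Among the measured compounds shown here, the single measured step, a number at least 6.8 percentage points higher from compound 1 to compound 2 (that floor lies within the scatter), exchanges one halophenyl for another at a different position and reaches a limit, so its size is only a floor within the scatter; it does not test the loss of a chloro group and bears on the present change only loosely. For the measured compounds named here, no measured step therefore points to a shift beyond the scatter.

Compound 4 is accordingly expected to give about 80% in this assay, between 65% and 92%, which means an estimated step of a number 3.8 percentage points lower from compound 3 to compound 4 (within the scatter).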

Compound 4, a percentage reported as inhibition, at one concentration (the size of the read-out at that concentration, not a potency): 86.3%
Compound 4: middle estimate off by 6.3 percentage points, on the low side, and the stated range covers the measured number.
By their numbers in this assay, from the lowest: compounds 1, 3 and 4 (each within the scatter of the next). At a limit, above all of these: compound 2.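

In this assay, exchanging 2,3-dichlorophenyl for 2-chlorophenyl gives a number 2.5 percentage points higher from compound 3 to compound 4 (within the scatter), so hydrogen can stand in place of the chloro group at this position, ortho to a chloro group and meta to a large group, with no difference that can be told from the scatter. Among the compounds shown here, the one earlier step between halophenyl groups ended at a limit, whereas this step has plain numbers at both ends and its size can be read directly. Nothing among the results shown offers a cause for this outcome.

Going by these compounds, whether an amine, a methoxy group or a carboxylic acid at this position would give a similar result remains open. So does whether a phenyl group without any chloro group would keep the read-out, and whether the same exchange would behave alike on the core of compound 1.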